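This account rests on a few compounds, and the source may have more. Where it says the series, first, only, none or still open, it means among the compounds named here.

Compound 1 `O=C(Nc1cccc(C(=O)O/N=C2\CCCc3onc(-c4cccc(F)c4)c32)c1)c1cccc(F)c1`, compound 2 `O=C(Nc1cccc(C(=O)O/N=C2\CCCc3noc(-c4cccc(F)c4)c32)c1)c1cccc(F)c1` and compound 3 `O=C(Nc1cccc(C(=O)O/N=C2\CCCc3onc(-c4ccccc4F)c32)c1)c1cccc(F)c1` share one core and were tested in a functional assay on HCC1954 cells (Homo sapiens) for antiproliferative activity, read by MTT assay, with a stated time of 72 h; a lower number here means a stronger inhibitor, a higher number a weaker inhibitor. In this assay compound 1 gives > 25000 nM, a limit of the assay rather than a number. Compound 2 likewise reaches only a limit, > 25000 nM. Compound 3 too gives only a limit, > 25000 nM. The step that the two limits leave unreadable from compound 1 to compound 3 therefore cannot be read because of the limit of > 25000 nM in this assay, at which 3 of the 3 values shown sit. Compound 3 thus stands only at a limit in this assay, with no measured number. Compound 4 `COc1ccc(-c2noc3c2/C(=N/OC(=O)c2cccc(NC(=O)c4cccc(F)c4)c2)CCC3)cc1OC` differs from it by 3,4-dimethoxyphenyl in place of 2-fluorophenyl on an aromatic carbon. No readable measured step bears on this change, and since every measured compound sits at the limit, compound 4 is expected to stay weak, with an estimated step of a number no higher from compound 3 to compound 4 (the limit leaves the size open). Compound 4 is estimated at 25000 nM, between 8000 nM and 70000 nM.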

Compound 4, half-maximal inhibitory concentration: > 25000 nM
Compound 4 was reported as a limit; the forecaster's own chance of this, stated with the estimate: 70%; the middle value lies on the limit itself.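

In this assay no new step can be read from compound 4 to compound 3 or compound 1, for this reason: the limit of > 25000 nM in this assay, at which 4 of the 4 values shown sit. The compounds shown leave open which change to the shared core, if any, would give a measurable potency.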